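The compounds below may be only part of what the source reports. "The series", "measured", "known", "first", "only" and "open" are said of these compounds alone.

Compound 1, `CCC(=O)Nc1ccc(-c2nc3cc(C(F)(F)F)ccc3n2C2CCCCC2)cc1`: > 100000 nM
Compound 2, `CCC(=O)Nc1ccc(-c2nc3cc(C(F)(F)F)ccc3[nH]2)cc1`: > 100000 nM
Compound 3, `CCC(=O)Nc1ccc(-c2nc3cc(C(F)(F)F)ccc3n2C)cc1`: > 100000 nM

In an ADME assay on Vero cells (Chlorocebus sabaeus) for cytotoxicity (a higher number here means that more compound is tolerated, a lower number that less compound is tolerated), compound 1 gives > 100000 nM, which is a limit of the assay rather than a number. Compound 2 likewise gives > 100000 nM, again a limit. Compound 3 gives > 100000 nM, also a limit. Between these three compounds the group on the aromatic nitrogen of the shared core is exchanged: a step that the two limits leave unreadable from compound 1 to compound 2, a step that the two limits leave unreadable from compound 1 to compound 3 and a step that the two limits leave unreadable from compound 2 to compound 3. None of these steps can be read, since all three values sit at the limit of > 100000 nM in this assay, at which 3 of the 3 values shown sit.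

Compound 4, `Nc1ccc(-c2nc3cc(C(F)(F)F)ccc3n2C2CCCCC2)cc1`, differs from compound 1 at the other end of the molecule: hydrogen in place of propanoyl on a nitrogen on an aromatic ring. Among the measured compounds shown here, no measured step touches the propanoyl; every measured compound carries it. The measured steps therefore tell nothing about this change, and nothing points to a shift beyond the scatter in this assay. Compound 4 is expected to give 100000 nM, estimated to lie between 30000 nM and 300000 nM. This estimate means a number no higher from compound 1 to compound 4 (the limit leaves the size open), with a limit again the most likely outcome.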

Compound 4, half-maximal cytotoxic concentration: > 100000 nM
Compound 4 was reported as a limit (the forecaster's own chance of this, stated with the estimate: 70%); the middle value lies on the limit itself.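

Compound 1 and compound 4 both give a limit of the assay rather than a number, and the step between them cannot be read. Whether the propanoyl or the group on the aromatic nitrogen has any bearing on the outcome in this assay stays open: no compound shown gives a number there.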